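The source may hold more compounds than are shown below. What is called first, only, known or untested is meant among the compounds shown, and "the series" means these compounds.

Among the measured compounds shown here, compound 2 `COc1cc2c(cc1N1CCN[C@H](C)C1)N(S(=O)(=O)c1ccc(-c3ccccn3)s1)CC2` gives the lowest of the two numbers measured so far. In a functional assay for agonist activity at growth hormone secretagogue receptor type 1 (Homo sapiens), read by FLIPR (a higher number here means that more compound is needed for the effect, a lower number that less compound is needed), compound 2 gives 3.98 nM, while compound 1 `COc1cc2c(cc1N1C[C@@H](C)N(C)[C@@H](C)C1)N(S(=O)(=O)c1ccc3ccccc3c1)CC2` gives 39.8 nM, a gap beyond the scatter; these two compounds differ in more than one place, so that gap is not tied to a single change. Compound 3 `COc1cc2c(cc1N1C[C@@H](C)NC(C)(C)C1)N(S(=O)(=O)c1ccc(-c3ccccn3)s1)CC2` has not yet been measured. It differs from compound 2 by a group of 9 heavy atoms (7 carbon, 2 nitrogen; one six-membered non-aromatic ring with 2 hetero atoms) in place of a group of 7 heavy atoms (5 carbon, 2 nitrogen; one six-membered non-aromatic ring with 2 hetero atoms), on an aromatic carbon. For the measured compounds named here, no measured pair matches this change, so the expectation rests on compound 2 alone. A small loss is expected, a 2.0-fold higher number from compound 2 to compound 3 (0.30 log units; within the scatter), possibly within the scatter. Compound 3 is estimated at 8 nM, within a range from 2.5 nM to 30 nM.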

Compound 3, half-maximal effective concentration: 10 nM
Compound 3: the middle estimate sits 1.3-fold (0.10 log units) below what was measured; the measured number falls inside the stated range.
By their numbers in this assay, from the lowest: compound 2; then compound 3; then compound 1.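

Swapping the 3-methylpiperazin-1-yl group on this aromatic carbon for the larger group with the same type of ring gives a 2.5-fold higher number from compound 2 to compound 3 (0.40 log units; beyond the scatter) in this assay. Among the compounds shown here, this is the first single change that can be read here, and it shows that this position accepts a larger ring group at only a modest cost. No measurement is available that explains the shift. As far as these compounds go, it remains open how an unsubstituted piperazin-1-yl group or an open-chain amine would behave at this position. From the compounds shown here alone, whether the same step would appear with the sulfonyl group of compound 1 also remains unknown.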